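Compound 2 and Its Unmeasured Neighbour, Compound 4

The source may report more compounds than this note shows. Statements on the series, on what has been measured and on what is new or still open speak of the compounds shown alone.

Of the compounds shown here, three sharing one core have been tested in a functional assay on SEM cells (Homo sapiens) for cytotoxicity, with a stated time of 72 h; on this read-out higher numbers stand for an effect only at larger amounts of compound and lower numbers for an effect already at smaller amounts. Compound 1 (`C=C[C@@](C)(/C=C/c1ccc(OCc2ccccc2)cc1)CCC=C(C)C`) gives > 36600 nM as a limit of the assay, not a number. Compound 2 (`C=C[C@@](C)(/C=C/c1ccc(Nc2cc(F)cc(F)c2)cc1)CCC=C(C)C`) gives > 36600 nM as a limit as well. Compound 3 (`C=C[C@@](C)(/C=C/c1ccc(Nc2cc(F)c(F)cc2F)cc1)CCC=C(C)C`) gives > 36600 nM as a limit too. Compound 2 thus has no number of its own, and the two results beside it offer none either: the whole set rests on the limit of > 36600 nM in this assay, at which 3 of the 3 values shown sit, so far.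

Compound 4 (`C=C[C@@](C)(/C=C/c1ccc(-c2cccc(F)c2)cc1)CCC=C(C)C`) has not yet been measured. In it, 3-fluorophenyl stands in place of (3,5-difluorophenyl)amino on an aromatic carbon, and the counted difference reads 3-fluorophenyl in place of (3,5-difluorophenyl)amino on an aromatic carbon for this exchange.

Among the compounds with values here, two measured steps bear on it. The exchange of benzyloxy for (3,5-difluorophenyl)amino is a step that the two limits leave unreadable from compound 1 to compound 2 and the change of the fluorinated ring on the nitrogen is a step that the two limits leave unreadable from compound 2 to compound 3 in the same test. Neither gives a size or a direction to carry over. The estimated change is a step that the limit leaves unreadable from compound 2 to compound 4 with no firm direction expected. A result that is again only a limit is the likeliest outcome. The estimated value for compound 4 is 40000 nM within an expected range of 15000 nM to 100000 nM in this assay when a number is obtained.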

Compound 4, half-maximal effective concentration: > 36600 nM
Compound 4: no number, only a limit (the forecaster's own chance of this, stated with the estimate: 80%); the middle value is on the limit's open side.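

With compound 4 again giving only a limit in this assay, no step can be read among compound 1, compound 2 and compound 4. The compounds shown leave open whether any exchange on the shared core changes the read-out at all, and where each compound truly lies, for all of them rest on one limit: the limit of > 36600 nM in this assay, at which 4 of the 4 values shown sit.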